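From Morpholine Amide to Methoxypyrrolidine Amide

The source may report more compounds than this note shows. Statements on the series, on what has been measured and on what is new or still open speak of the compounds shown alone.

Of the compounds shown here, three sharing one core have been measured in a functional assay on MIA PaCa-2 cells (Homo sapiens) for inhibition, read by MTT assay, with a stated time of 3 days; on this read-out lower numbers stand for stronger inhibition and higher numbers for weaker inhibition. Compound 1 `O=C([C@@H]1CCCN(S(=O)(=O)c2ccc(S(=O)(=O)C3CCC3)cc2)C1)N1CCC(F)(F)CC1` gives 12.6 nM, compound 3 `CN(C)S(=O)(=O)c1ccc(S(=O)(=O)N2CCC[C@@H](C(=O)N3CCC(F)(F)CC3)C2)cc1` gives 72.4 nM, and compound 2 `CCN(CC)S(=O)(=O)c1ccc(S(=O)(=O)N2CCC[C@@H](C(=O)N3CCOCC3)C2)cc1` gives 160 nM. Compound 2 therefore stands highest of the three numbers, with compound 3 nearest and compound 1 furthest. Within the data shown here, the one single-place step measured, a 5.7-fold higher number from compound 1 to compound 3 (0.76 log units; beyond the scatter), lies on the sulfonyl sulfur and not on the amide.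

Compound 4 `CCN(CC)S(=O)(=O)c1ccc(S(=O)(=O)N2CCC[C@@H](C(=O)N3CC[C@@H](OC)C3)C2)cc1` differs from compound 2 at the carbonyl carbon: 3-methoxypyrrolidin-1-yl in place of morpholin-4-yl on a carbonyl carbon. Among the measured compounds shown here, no measured step touches this place. Compound 1 and compound 3 carry the same amide as each other, and the gap between compound 2 and compound 3 mixes an amide change with a change on the sulfonyl sulfur, so it isolates nothing. The account therefore expects no step beyond the scatter, no change at the digits printed from compound 2 to compound 4 (within the scatter), in this assay. For compound 4 the estimate in this assay is 160 nM, within 50 nM to 500 nM.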

Compound 4, half-maximal inhibitory concentration: 1070 nM
Compound 4: the middle estimate sits 6.7-fold (0.83 log units) below what was measured; measured number above the stated range.
By their numbers in this assay, from the lowest: compound 1; then compound 3; then compound 2; then compound 4.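

Among these compounds, the amide place, which no earlier step had touched, proves not to be silent: in this assay this one change gives a 6.7-fold higher number from compound 2 to compound 4 (0.83 log units; beyond the scatter) and so shows that the group on the carbonyl carbon counts for this read-out. The change replaces a six-membered non-aromatic ring with 2 hetero atoms by a five-membered one with 1 hetero atom and a defined stereocentre, while the count of hydrogen-bond acceptors stays the same, so that count does not follow the step in this pair. Nothing measured here bears on why the number rises.

The ring change and the methoxy group remain unseparated, and a plain pyrrolidin-1-yl or a 4-methoxypiperidin-1-yl on the carbonyl carbon would be needed to part them. Also open, from the compounds shown here alone, is whether the opposite stereocentre of the 3-methoxypyrrolidin-1-yl would give a similar number.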